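Swapping 4-Fluorophenyl for 2-Fluorophenyl on an Imine Carbon

This account rests on a few compounds, and the source may have more. Where it says the series, first, only, none or still open, it means among the compounds named here.

Measured so far:
Compound 1 `Nc1sc2c(c1-c1nc3cc(Cl)ccc3s1)CCC2`: 59.1 ug/mL in an ADME assay on cells (Rhabdomyosarcoma cell, Homo sapiens) for cytotoxicity, read by MTT assay, with a stated time of 72 h; on this read-out lower numbers stand for higher toxicity in this test and higher numbers for lower toxicity in this test
Compound 2 `Fc1ccc(/C=N/c2sc3c(c2-c2nc4ccccc4s2)CCC3)cc1`: 290 ug/mL in this assay

Compound 2 gives the higher of the two numbers in this assay, and compound 1 gives a lower one, a gap beyond the usual scatter; the two differ in several places at once, so only the values themselves can be compared. Compound 3 `Fc1ccccc1/C=N/c1sc2c(c1-c1nc3ccccc3s1)CCC2` differs from compound 2 in one way: 2-fluorophenyl in place of 4-fluorophenyl on a carbon with a double bond to nitrogen. Among the measured compounds shown here, no measured pair shows this change. A step from compound 2 to compound 3 of a 1.2-fold lower number from compound 2 to compound 3 (0.06 log units; within the scatter) is expected, no more than the scatter. Compound 3 is estimated at 250 ug/mL, between 120 ug/mL and 500 ug/mL.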

Compound 3, half-maximal cytotoxic concentration: 270 ug/mL
For compound 3 the middle estimate is 1.1-fold (0.03 log units) below the measured one, and the stated range covers the measured number.
By their numbers in this assay, from the lowest: compound 1; then compounds 3 and 2 (each within the scatter of the next).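

In this assay the swap of 4-fluorophenyl for 2-fluorophenyl on a carbon with a double bond to nitrogen gives a 1.1-fold lower number from compound 2 to compound 3 (0.03 log units; within the scatter). Among the compounds shown here, this is the first comparison at this position, and it shows that moving the fluorine around this phenyl ring leaves the cytotoxicity number unchanged within the scatter. Nothing available explains why the two compounds read alike.

Going by these compounds, whether 3-fluorophenyl would read the same remains open. So does whether a different group on this ring, such as an amine or a carboxylic acid, would shift the number.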